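Replacing the aryl group on the hydrazide nitrogen of compound 1

The compounds below may be only part of what the source reports. "The series", "measured", "known", "first", "only" and "open" are said of these compounds alone.

Measured so far:
compound 1, `Cc1ccccc1NNC(=O)c1ccc(NS(=O)(=O)c2cnc(O)nc2O)cc1`: > 20000 nM
compound 2, `O=C(NNc1cccc(Cl)c1)c1ccccc1NS(=O)(=O)c1cnc(O)nc1O`: 10800 nM

In a functional assay on SGC-7901 cells (Homo sapiens) for antiproliferative activity, read by MTT assay, with a stated time of 24 h (on this read-out lower numbers stand for stronger inhibition and higher numbers for weaker inhibition), compound 1 gives > 20000 nM, and this is a limit of the assay rather than a number: the compound stands at the limit of > 20000 nM in this assay, at which 1 of the 2 values shown sits. Compound 2, a differently substituted relative, gives 10800 nM in this assay, so it is the one of the two with an actual number; since the two differ in more than one place, no single step can be read between them.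

Compound 3 is `O=C(NNC(=O)c1ccccc1F)c1ccc(NS(=O)(=O)c2cnc(O)nc2O)cc1`. Compared with compound 1 the change is (2-fluorophenyl)carbonyl in place of 2-methylphenyl on an amine nitrogen. Both measured compounds sit in the weak region of this assay, and compound 1 itself gives only a limit, so the step from compound 1 to compound 3 is expected to be small or absent, an at least 1.2-fold lower number from compound 1 to compound 3 (0.09 log units; that floor lies within the scatter), with the result most likely again near or at the limit. Compound 3 is therefore estimated at 16000 nM in this assay, within a range from 5000 nM to 40000 nM, and a limit rather than a number is a real possibility.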

Compound 3, half-maximal inhibitory concentration: > 20000 nM
Compound 3: a limit, no number (the forecaster's own chance of this, stated with the estimate: 45%); at least 1.2-fold (0.09 log units) between middle value and limit.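

In this assay compound 3 gives > 20000 nM as a limit of the assay and not a number. Compound 1 gives > 20000 nM as a limit too, so no step can be read between compound 1 and compound 3. The compounds shown leave open whether (2-fluorophenyl)carbonyl in place of 2-methylphenyl changes the activity at all.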